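The compounds below may be only part of what the source reports. "The series", "measured", "known", "first", "only" and "open" are said of these compounds alone.

Measured in a physicochemical assay for solubility, in phosphate buffer, at pH 7.4; on this read-out lower numbers stand for lower solubility and higher numbers for higher solubility:

- Compound 1 `CC(C)n1cc(-c2ccnc3[nH]c(C4CCN(CC(=O)N(C)C)CC4)cc23)cnc1=O`: 910000 nM
- Compound 2 `CC(C)n1cc(-c2ccnc3[nH]c(C4CCN(CC(=O)N5CCCCC5)CC4)cc23)ccc1=O`: 79000 nM
- Compound 3 `COc1cc(C(=O)N2CCCC2)ccc1-c1ccnc2[nH]c(C3CCNCC3)cc12`: 590000 nM

Compound 1, at 910000 nM, and compound 3, at 590000 nM, lie within the usual scatter of each other. Compound 2, at 79000 nM, stands lower than compound 1, and that gap lies beyond the scatter.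

Compound 4 `CN(C)C(=O)CN1CCC(c2cc3c(-c4ccc(=O)n(C)c4)ccnc3[nH]2)CC1` has not yet been measured. It differs from compound 1 in one place, on an aromatic carbon of the shared core: a group of 8 heavy atoms (6 carbon, 1 nitrogen, 1 oxygen; one six-membered aromatic ring with 1 hetero atom) in place of a group of 10 heavy atoms (7 carbon, 2 nitrogen, 1 oxygen; one six-membered aromatic ring with 2 hetero atoms), on an aromatic carbon. For the measured compounds named here, no two measured compounds differ in one place only, so the effect of this change in this assay has not been isolated. Little or no change beyond the scatter is expected, with any shift more likely downward. The expected change is a 1.5-fold lower number from compound 1 to compound 4 (0.18 log units; within the scatter). The low end of the range is kept wide since compound 2 gives 79000 nM in this small set. The estimated value for compound 4 is 600000 nM, with an expected range from 200000 nM to 1300000 nM.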

Compound 4, solubility: > 1000000 nM
Compound 4: a limit, no number (the forecaster's own chance of this, stated with the estimate: 10%); middle value at least 1.6-fold (0.22 log units) from the limit.
By their numbers in this assay, from the lowest: compound 2; then compounds 3 and 1 (each within the scatter of the next). At a limit, above all of these: compound 4.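

In this assay compound 4 gives > 1000000 nM, which is a limit of the assay and not a number. On the aromatic carbon opposite the ring nitrogen, placing the group of 8 heavy atoms where the group of 10 heavy atoms stood gives an at least 1.0-fold higher number from compound 1 to compound 4 (0.04 log units; that floor lies within the scatter), so this first isolated change at the position shows no fall in solubility. The size of the step stays unknown because compound 4 stands at a limit: the limit of > 1000000 nM in this assay, at which 1 of the 4 values shown sits.

The compounds shown leave open how a group carrying an amine or a carboxylic acid would read at this aromatic carbon. For the compounds shown here, they also leave open whether the same exchange gives a similar step when the shared core bears a different chain from the one in compound 1.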